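A few compounds are considered here, and "the series" means these few. Any claim that something is new, unique, unknown or untested is made for them only; others in the source may bear on it.

Measured so far in the series:
- compound 1, `O=C(O)CCC(=O)/C=C/c1cn(-c2ccccc2)nc1-c1ccccc1`: 23.5%
- compound 2, `NC(=O)c1ccccc1NC(=O)c1cn(-c2ccccc2)nc1-c1ccc(Cl)cc1`: 9.26%
- compound 3, `CC(=O)Nc1ccc(OC(=O)c2cn(-c3ccccc3)nc2-c2ccc(Cl)cc2)cc1`: 16.1%

All three numbers come from a functional assay on the whole organism (strain albino) for inhibition, with Rattus norvegicus as the target, read by paw edema, with stated times of 30 min and 4 h, at a dose of 50 mg/kg by the oral route; a lower number here means less inhibition, a higher number more inhibition at the dose given (going by the name of the read-out). Compound 1 gives 23.5%, compound 2 gives 9.26% and compound 3 gives 16.1%. On these numbers compound 3 stands second highest of the three; its nearest neighbour is compound 2, whose number is lower by a gap that lies within the scatter, and the furthest is compound 1, whose number is higher by a gap that also lies within the scatter. With every gap inside the scatter, no order among the three can be read from the figures so far.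

The next compound, compound 4, `CC(=O)Nc1ccc(OC(=O)c2cn(-c3ccccc3)nc2-c2ccc(C)cc2)cc1`, keeps everything of compound 3 except one substituent: methyl in place of chloro on an aromatic carbon. Among the measured compounds shown here, no pair of measured compounds differing in one place is available, so there is no measured step to lean on; the change is a single heavy atom swapped for another, without any change in ring count, donors, acceptors or charge.

The expectation for this assay is therefore a step of a number 1.1 percentage points lower from compound 3 to compound 4 (within the scatter) from compound 3, which is no change beyond the scatter. Compound 4 is estimated at 15%, within the range 4% to 28%.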

Compound 4, a percentage reported as inhibition, in the whole organism at one dose (the size of the read-out at that dose, not a potency): 3.7%
Beside the measured number, compound 4's estimate is 11.3 percentage points above it, and the stated range ends above it.
By their numbers in this assay, from the lowest: compounds 4, 2, 3 and 1 (each within the scatter of the next, the first and the last beyond it).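

Among the compounds shown here, this is the first step that isolates one place: in this assay, methyl in place of chloro on the aromatic carbon para to a large group gives a number 12.4 percentage points lower from compound 3 to compound 4 (beyond the scatter), so the read-out at this dose is sensitive to the substituent at this position. The two groups are each a single heavy atom, and neither brings a ring, a hydrogen-bond donor, a hydrogen-bond acceptor or a net charge, so these counts do not separate compound 3 from compound 4, and a change this small in those terms is enough to move the number beyond the scatter. Nothing available here accounts for the step, which for now stands as an observation on this single pair.

From the compounds shown here alone, with only chloro and methyl seen at this position, the pair gives no trend, and it remains open how fluoro, methoxy or an amine in the same place would read in this assay. Going by these compounds, it also remains open whether the same swap would give a similar step with the other side chains, such as that of compound 2.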